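The compounds below may be only part of what the source reports. "The series", "measured", "known", "first", "only" and "open" are said of these compounds alone.

Measured compounds:

- compound 1, `COc1cc2c(Oc3ccc(NC(=O)NN4C(=O)CSC4c4c(F)cccc4F)c(Cl)c3)ccnc2cc1OCCCN1CCCC1`, gives 960 nM in a functional assay on A549 cells (Homo sapiens) for antiproliferative activity, read by MTT assay, with a stated time of 72 h; a higher number here means a weaker inhibitor, a lower number a stronger inhibitor
- compound 2, `COc1cc2c(Oc3ccc(NC(=O)NN4C(=O)CSC4c4c(F)cccc4F)cc3Cl)ccnc2cc1OCCCN1CCCC1`, gives 880 nM in this assay
- compound 3, `COc1cc2c(Oc3c(F)cc(NC(=O)NN4C(=O)CSC4c4c(F)cccc4F)cc3F)ccnc2cc1OCCCN1CCCC1`, gives 560 nM in this assay

Compound 3 shows the lowest of the three numbers, but the values of compound 2 and compound 1 both lie within the scatter of it, so no order among the three can be read from these data. Among the measured compounds shown here, no single-point step between measured compounds is available.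

Compound 4, `COc1cc2c(Oc3c(F)cc(NC(=O)NN4C(=O)CSC4c4c(F)cccc4F)cc3F)ccnc2cc1OCCCN1CCC(N2CCCCC2)CC1`, keeps the whole of compound 3 except for one change: 4-(piperidin-1-yl)piperidin-1-yl in place of pyrrolidin-1-yl on a saturated chain carbon, three bonds along the chain from an oxygen on an aromatic ring. Nothing in the measured set reports what such a change on the chain does, so the expectation rests on the value of compound 3 alone. The expected step from compound 3 to compound 4 is a 1.0-fold lower number from compound 3 to compound 4 (0.01 log units; within the scatter), that is, no change beyond the scatter in either direction. For compound 4 in this assay the estimate is 550 nM, with a range from 180 nM to 1700 nM.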

Compound 4, half-maximal inhibitory concentration: 380 nM
Beside the measured number, compound 4's estimate is 1.4-fold (0.16 log units) above it; the range from low to high includes it.
By their numbers in this assay, from the lowest: compounds 4, 3, 2 and 1 (each within the scatter of the next, the first and the last beyond it).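

In this assay, 4-(piperidin-1-yl)piperidin-1-yl in place of pyrrolidin-1-yl on a saturated chain carbon, three bonds along the chain from an oxygen on an aromatic ring, gives a 1.5-fold lower number from compound 3 to compound 4 (0.17 log units; within the scatter) at this place. The earlier compounds shown here all carried pyrrolidin-1-yl here and so said nothing about this position; now a group of 12 heavy atoms with two six-membered rings, in place of one of 5 heavy atoms with a single five-membered ring, leaves the number within the scatter. No measurement is at hand that would explain this result.

The compounds shown leave open how a morpholin-4-yl or a dimethylamino group would read at this place, and what a longer chain would do. They also leave open whether the same exchange would give a similar step on compound 1 or compound 2.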